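This account rests on a few compounds, and the source may have more. Where it says the series, first, only, none or still open, it means among the compounds named here.

Compounds measured so far:
compound 1, `CCCCOC(=O)Nc1ccc([Se]C#N)cc1`, 5000 nM;
compound 2, `N#C[Se]c1ccc(NC(=O)Oc2ccc(F)cc2)cc1`, 19800 nM.

Both were tested in an ADME assay on BEAS-2B cells (Homo sapiens) for cytotoxicity, read by MTT assay, with a stated time of 72 h; a lower number here means a stronger inhibitor of growth, a higher number a weaker inhibitor of growth. Compound 2 stands at the higher of the two numbers, so it is the weaker inhibitor of growth of the pair; compound 1 gives 5000 nM, a lower number that lies beyond the scatter of the assay. The step to be followed is from compound 2 to compound 3, `N#C[Se]c1ccc(NC(=O)Oc2ccccc2)cc1`. It consists of hydrogen in place of fluoro on an aromatic carbon, the fluoro leaving the outer ring of the carbamate and a hydrogen taking its place; the rest of the molecule is kept. Within the data shown here, there is no measured pair in this set showing what such a change does, so the expectation rests only on its small size. Compound 3 is expected to stay close to compound 2, with a step of a 1.2-fold lower number from compound 2 to compound 3 (0.09 log units; within the scatter) that should not exceed the scatter. Compound 3 is therefore estimated at 16000 nM in this assay, within a range from 7000 nM to 36000 nM.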

Compound 3, concentration for 50% growth inhibition: 8900 nM
For compound 3 the middle estimate is 1.8-fold (0.25 log units) above the measured one; the measured number falls inside the stated range.
By their numbers in this assay, from the lowest: compounds 1 and 3 (each within the scatter of the next); then compound 2.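

In this assay, the fluoro para to a large group on the outer aromatic ring now has a measured counterpart, and hydrogen in place of fluoro gives a 2.2-fold lower number from compound 2 to compound 3 (0.35 log units; beyond the scatter), a modest step that shows this single atom moves the number beyond the scatter. On the oxygen next to a carbonyl group, phenyl in place of butyl gives a 1.8-fold higher number from compound 1 to compound 3 (0.25 log units; within the scatter), so among these compounds the butyl and the unsubstituted phenyl cannot be told apart, and only compound 2, which carries the fluoro, stands apart from both. Nothing measured here accounts for either step.

Going by these compounds, whether a chloro or a methoxy at the same place would act as the fluoro does remains open. Also open, on these data alone, is whether a longer chain or a benzyl on the oxygen would stay level with butyl and phenyl.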